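The compounds below may be only part of what the source reports. "The series", "measured", "known", "first", "only" and "open" are said of these compounds alone.

Measured compounds:
compound 1 `Fc1ccc(Nc2cc3[nH]c(-c4cccc(C(F)(F)F)c4)nc3cn2)nc1` — < 5000 nM
compound 2 `FC(F)(F)c1ccc(Nc2cc3[nH]c(-c4cccc(C(F)(F)F)c4)nc3cn2)nc1` — < 5000 nM
compound 3 `Fc1ccc(-c2nc3cnc(Nc4ccc(C(F)(F)F)cn4)cc3[nH]2)cc1F` — < 5000 nM

Notes. In a physicochemical assay for solubility, using the shake flask method, in phosphate buffer, measured as kinetic solubility, with a stated time of 20 h, at pH 6.5 (on this read-out lower numbers stand for lower solubility and higher numbers for higher solubility), compound 1 gives < 5000 nM, which is a limit of the assay and not a number. In this assay compound 2 likewise gives < 5000 nM, a limit. In this assay compound 3 gives < 5000 nM, again a limit. The three values therefore share (the limit of < 5000 nM in this assay, at which 3 of the 3 values shown sit), and no ordering among them can be read.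

The change from compound 2 to compound 1 is fluoro in place of trifluoromethyl on an aromatic carbon; its step in this assay is a step that the two limits leave unreadable from compound 2 to compound 1. The change from compound 2 to compound 3 is 3,4-difluorophenyl in place of 3-(trifluoromethyl)phenyl on an aromatic carbon; its step is a step that the two limits leave unreadable from compound 2 to compound 3.

Compound 4 `Fc1ccc(Nc2cc3[nH]c(-c4ccc(F)c(F)c4)nc3cn2)nc1` has not been measured. It differs from compound 3 by fluoro in place of trifluoromethyl on an aromatic carbon. This is the same change as that from compound 2 to compound 1; the place lines of the two read alike word for word, and the cores on which the change sits differ by 3,4-difluorophenyl in place of 3-(trifluoromethyl)phenyl on an aromatic carbon.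

The step from compound 3 to compound 4 in this assay is expected to be a step that the limit leaves unreadable from compound 3 to compound 4, set beside the earlier one, which rests on a step that the two limits leave unreadable from compound 2 to compound 1 being unreadable and on (the limit of < 5000 nM in this assay, at which 3 of the 3 values shown sit), at which every measured compound sits. Compound 4 is expected to give about 2000 nM in this assay, estimated to lie between 300 nM and 6000 nM, most likely reported again only as a limit.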

Compound 4, solubility: < 5000 nM
Compound 4: a limit, no number; the forecaster's own chance of this, stated with the estimate: 85%; the middle value does not contradict the limit.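

In this assay compound 4 gives < 5000 nM, a limit and not a number. Compound 3 is also known only as a limit, so no step can be read from compound 3 to compound 4, and the series stays at a single limit: the limit of < 5000 nM in this assay, at which 4 of the 4 values shown sit.

The compounds shown leave open where each true value lies, and so whether fluoro in place of trifluoromethyl changes the read-out at all.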